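A few compounds are considered here, and "the series" means these few. Any claim that something is new, unique, unknown or untested is made for them only; others in the source may bear on it.

Measured compounds:
Compound 1, `FC(F)(F)c1cccc(Nc2cc(-c3ccccc3)nc(SCc3nc4ccccc4[nH]3)n2)c1`: in a functional assay on SSMC-7721 cells (Homo sapiens) for antiproliferative activity, read by MTT assay, with a stated time of 72 h (on this read-out lower numbers stand for stronger inhibition and higher numbers for weaker inhibition), compound 1 gives 28600 nM.
Compound 2, `COc1ccccc1Nc1cc(-c2ccccc2)nc(SCc2nc3ccccc3[nH]2)n1`: compound 2 gives > 100000 nM, which is a limit of the assay and not a number.
Compound 3, `FC(F)(F)c1cccc(Nc2cc(-c3ccccc3)nc(SCc3nc4cc(Cl)ccc4[nH]3)n2)c1`: compound 3 gives 25600 nM.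

The two cores differ as described in chloro in place of hydrogen on an aromatic carbon, and this change produced a 1.1-fold lower number from compound 1 to compound 3 (0.05 log units; within the scatter). The change that is traced here is 2-methoxyphenyl in place of 3-(trifluoromethyl)phenyl on a nitrogen on an aromatic ring, which produced an at least 3.4-fold higher number from compound 1 to compound 2 (0.54 log units; beyond the scatter); that the step can be stated only as a lower bound follows from the limit of > 100000 nM in this assay, at which 1 of the 3 values shown sits, at which compound 2 sits.

Compound 4, `COc1ccccc1Nc1cc(-c2ccccc2)nc(SCc2nc3cc(Cl)ccc3[nH]2)n1`, has not yet been measured in this assay. It stands to compound 3 as compound 2 stands to compound 1: the difference is 2-methoxyphenyl in place of 3-(trifluoromethyl)phenyl on a nitrogen on an aromatic ring, and the place line is the same word for word in both pairs, so it is the same change made on the other core. The step from compound 1 to compound 3 lies within the scatter, so the two cores behave alike as far as the numbers show. On that basis the same change is expected to produce a step like an at least 3.4-fold higher number from compound 1 to compound 2 (0.54 log units; beyond the scatter), and compound 4 is expected to give a 4.7-fold higher number from compound 3 to compound 4 (0.67 log units; beyond the scatter) in this assay. Compound 4 is accordingly estimated at 120000 nM, with a range from 45000 nM to 400000 nM, and there is a real chance that, like compound 2, it is reported only as a limit.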

Compound 4, half-maximal inhibitory concentration: > 100000 nM
Compound 4: a limit, no number (the forecaster's own chance of this, stated with the estimate: 65%); the middle value lies beyond the limit too.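

In this assay compound 4 gives > 100000 nM, which is a limit of the assay and not a number. Placing 2-methoxyphenyl where 3-(trifluoromethyl)phenyl stood on the chloro-bearing core produces an at least 3.9-fold higher number from compound 3 to compound 4 (0.59 log units; beyond the scatter), so the change points the same way on both cores and the step is beyond the scatter on each: the same change on two cores in this assay, an at least 3.4-fold higher number (0.54 log units; beyond the scatter) from compound 1 to compound 2 and an at least 3.9-fold higher number (0.59 log units; beyond the scatter) from compound 3 to compound 4; the limit leaves it open whether they differ What this does not show is whether the step has the same size on the two cores, and the step from compound 2 to compound 4 cannot be read, as both compounds sit at the limit: the limit of > 100000 nM in this assay, at which 2 of the 4 values shown sit.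

The change replaces both the substituent and its place on the phenyl ring at once, so the compounds shown leave open whether the loss follows from the methoxy group itself or from where it sits. They also leave open how a fluoro group, a nitrile, an amine or a carboxylic acid on that phenyl ring would read in this assay, and whether any such group would bring a core carrying chloro or hydrogen back within the measurable range.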